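The source may hold more compounds than are shown below. What is called first, only, known or untested is meant among the compounds shown, and "the series" means these compounds.

Measured in a functional assay with Homo sapiens as the target; on this read-out higher numbers stand for weaker inhibition and lower numbers for stronger inhibition:
- compound 1 `CC(C)[C@H](NC(=O)COc1cccc2ccccc12)C(=O)N[C@@H](CC(=O)O)C(=O)COc1ccccc1C(F)(F)F`: 17300 nM
- compound 2 `CC(C)[C@H](NC(=O)COc1cccc2ccccc12)C(=O)N[C@@H](CC(=O)O)C(=O)COc1ccc(Oc2ccccc2)cc1`: 19000 nM
- compound 3 `CC(C)[C@H](NC(=O)COc1cccc2ccccc12)C(=O)N[C@@H](CC(=O)O)C(=O)COc1ccc(Oc2ccc(C(F)(F)F)cc2)cc1`: 24900 nM

Compound 1 lies within the scatter of both compound 2 and compound 3, so the three values give no order. Compound 4 `CC(C)[C@H](NC(=O)COc1cccc2ccccc12)C(=O)N[C@@H](CC(=O)O)C(=O)COc1ccccc1F` differs from compound 1 by fluoro in place of trifluoromethyl on an aromatic carbon, ortho to a large group. For the measured compounds named here, the only measured step involving trifluoromethyl is a 1.3-fold higher number from compound 2 to compound 3 (0.12 log units; within the scatter). It has hydrogen, not fluoro, as the partner group, so it bears on this change only loosely. No step beyond the scatter is expected in this assay. The estimate for compound 4 is 18000 nM, with an expected range from 9000 nM to 36000 nM. The expected change is a 1.0-fold higher number from compound 1 to compound 4 (0.02 log units; within the scatter).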

Compound 4, half-maximal inhibitory concentration: 15700 nM
For compound 4 the middle estimate is 1.1-fold (0.06 log units) above the measured one; the measured number falls inside the stated range.
By their numbers in this assay, from the lowest: compounds 4, 1, 2 and 3 (each within the scatter of the next).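

In this assay, fluoro in place of trifluoromethyl, on an aromatic carbon ortho to a large group, gives a 1.1-fold lower number from compound 1 to compound 4 (0.04 log units; within the scatter). For the compounds shown here, this is the first reading of a change at this position: the substituent shrinks from 4 heavy atoms to 1, and the step stays within the scatter. No measurement is available that would explain this result.

Still open, going by these compounds, is how an unsubstituted carbon, an amine or a carboxylic acid at this position would compare with the 2-fluorophenoxy group. On these data alone, whether any replacement here can give a step beyond the scatter also remains open.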